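Second methoxy on the stilbene core of compound 1

This account rests on a few compounds, and the source may have more. Where it says the series, first, only, none or still open, it means among the compounds named here.

Compound 1, with the structure `COc1cccc(/C=C/c2ccc(F)cc2)c1`, shows the highest number among the three measured compounds in an assay on HepG2 cells for activation of nuclear factor erythroid 2-related factor 2 (Homo sapiens), read by a luciferase reporter, with a stated time of 5 h (on this read-out lower numbers stand for an effect already at smaller amounts and higher numbers for an effect only at larger amounts of compound), where compound 1 gives 6000 nM. Two neighbours carry one added methoxy each. Compound 2, with the structure `COc1ccc(/C=C/c2ccc(F)cc2)cc1OC`, gives 2600 nM in this assay; compound 3, with the structure `COc1cccc(/C=C/c2ccc(F)cc2)c1OC`, gives 2900 nM. Both steps are modest but beyond the scatter: a 2.3-fold lower number from compound 1 to compound 2 (0.36 log units; beyond the scatter) and a 2.1-fold lower number from compound 1 to compound 3 (0.32 log units; beyond the scatter).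

Compound 4, with the structure `COc1ccc(OC)c(/C=C/c2ccc(F)cc2)c1`, is the next member of this set and differs from compound 1 by methoxy in place of hydrogen on an aromatic carbon, placed ortho to a group of 9 heavy atoms and para to a methoxy group. The two measured additions of a methoxy to compound 1 each lowered the number by a modest amount, and the change to compound 4 is of the same kind, so a modest step in the same direction is expected in this assay, about a 2.0-fold lower number from compound 1 to compound 4 (0.30 log units; within the scatter). For compound 4 the expected value is therefore 3000 nM, within a range of 1200 nM to 7500 nM.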

Compound 4, half-maximal effective concentration: 5100 nM
Estimate against measurement, compound 4: 1.7-fold (0.23 log units) below; low and high end bracket the measured number.
By their numbers in this assay, from the lowest: compounds 2, 3, 4 and 1 (each within the scatter of the next, the first and the last beyond it).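

In this assay the step of a 1.2-fold lower number from compound 1 to compound 4 (0.07 log units; within the scatter) stays within the scatter, so a methoxy placed ortho to a group of 9 heavy atoms and para to a methoxy group gives no readable change from the core of compound 1. The two earlier additions of a methoxy, a 2.3-fold lower number from compound 1 to compound 2 (0.36 log units; beyond the scatter) and a 2.1-fold lower number from compound 1 to compound 3 (0.32 log units; beyond the scatter) both lay beyond the scatter, so among these compounds the same change does not give the same result at every place on this ring. Nothing available explains why this position differs from the other two.

The compounds shown leave open whether this position tolerates only small changes or would respond to a different group, such as a hydroxyl, an amine or a carboxylic acid. They also leave open what a longer chain, such as ethoxy, would do there.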